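Swapping phenyl for naphthalen-2-yl on a thiazolidinone-like core

The source may report more compounds than this note shows. Statements on the series, on what has been measured and on what is new or still open speak of the compounds shown alone.

Compound 1 `O=C1CS/C(=N\c2csc(-c3ccccc3)c2)N1`: > 50000 nM
Compound 2 `O=C1N/C(=N/c2csc(-c3ccc(Cl)cc3)c2)S/C1=C\c1ccccc1`: 11200 nM

These two compounds share a core and were tested in a functional assay on HCT-116 cells (Homo sapiens) for cytotoxicity, read by MTT assay, with a stated time of 72 h; on this read-out lower numbers stand for stronger inhibition and higher numbers for weaker inhibition. The value for compound 1 is a limit of the assay and not a number, the case described by the limit of > 50000 nM in this assay, at which 1 of the 2 values shown sits. Among the compounds with values here, compound 2 is the only compound with a measured number; in this assay compound 2 gives 11200 nM. The other value is a limit. Within the data shown here, no step between measured compounds can be stated.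

Compound 3 `O=C1N/C(=N/c2csc(-c3ccc(Cl)cc3)c2)S/C1=C\c1ccc2ccccc2c1` has not yet been measured. It differs from compound 2 by naphthalen-2-yl in place of phenyl on a double-bonded chain carbon bound to a double-bonded ring carbon. The shared core and the chlorophenyl part are kept; only the aromatic group on the double-bonded chain carbon grows by one ring.

With no measured step of this kind in hand, the expectation can rest only on the single number for compound 2. The step from compound 2 to compound 3 is expected to be a 2.0-fold lower number from compound 2 to compound 3 (0.31 log units; beyond the scatter), a modest gain that may not exceed the usual scatter. For compound 3 in this assay the estimate is 5500 nM, within a range from 1500 nM to 20000 nM.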

Compound 3, half-maximal inhibitory concentration: 3000 nM
For compound 3 the middle estimate is 1.8-fold (0.26 log units) above the measured one; low and high end bracket the measured number.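

In this assay, within the data shown here, the aromatic group on the double-bonded chain carbon bound to a double-bonded ring carbon proves able to shift the read-out: naphthalen-2-yl in place of phenyl gives the first step that can be read (a 3.7-fold lower number from compound 2 to compound 3 (0.57 log units; beyond the scatter)). Among these compounds, the change keeps everything else in place, so this difference belongs to the one swapped group, and it shows that this position accepts a second aromatic ring with a modest gain in cytotoxicity rather than a loss. Nothing shown here explains why the larger group gives the lower number.

On these data alone, a single step cannot show a trend, so it remains open whether the gain follows from the added ring itself or would also appear with a different group at this place, such as cyclohexyl, pyridin-3-yl or a phenyl ring carrying a carboxylic acid. As far as these compounds go, it is also open whether the same swap would give a similar step with another group in place of the chlorophenyl part, or in cell lines other than this one.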